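Notes on a one-carbon spacer insertion, compound 1 to compound 4

The source may hold more compounds than are shown below. What is called first, only, known or untested is meant among the compounds shown, and "the series" means these compounds.

Measured compounds:
compound 1 `c1ccc2c(c1)CCC2NC1CCN(CCCc2c[nH]c3ccc(-n4cnnc4)cc23)CC1`: 25 nM
compound 2 `CC(=O)Nc1ccc(CNC2CCN(CCCc3c[nH]c4ccc(-n5cnnc5)cc34)CC2)cc1`: 5 nM
compound 3 `NC(=O)OC[C@H](NC1CCN(CCCc2c[nH]c3ccc(-n4cnnc4)cc23)CC1)c1ccccc1`: 9.3 nM

All three values come from an assay on CHO cells for agonist activity at 5-hydroxytryptamine receptor 1D (Homo sapiens), read by GTPgammaS binding; a lower number here means that less compound is needed, a higher number that more compound is needed for the effect. Compound 1 has the highest number of the three; its nearest neighbour is compound 3, with a 2.7-fold lower number from compound 1 to compound 3 (0.43 log units; beyond the scatter), and the furthest is compound 2, with a 5.0-fold lower number from compound 1 to compound 2 (0.70 log units; beyond the scatter). Between compounds 2 and 3 the gap is a 1.9-fold higher number from compound 2 to compound 3 (0.27 log units; within the scatter).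

Compound 4 `c1ccc2c(c1)CCC2NCC1CCN(CCCc2c[nH]c3ccc(-n4cnnc4)cc23)CC1` is not yet measured. It differs from compound 1 by ((2,3-dihydro-1H-inden-1-yl)amino)methyl in place of (2,3-dihydro-1H-inden-1-yl)amino on a saturated ring carbon. The change keeps the 2,3-dihydro-1H-inden-1-yl group and the amine hydrogen and only lengthens the link to the saturated ring carbon.

For the measured compounds named here, every measured step swaps the group on the amine nitrogen while the attachment to the saturated ring carbon stays as in compound 1; no step in this set alters that attachment. The measured steps are therefore only indirect guides, and they show that the set tolerates varied groups at this end without large swings. For compound 4 a step close to the scatter, if anything toward a higher number, is expected, on the order of a 1.6-fold higher number from compound 1 to compound 4 (0.20 log units; within the scatter). The estimate for compound 4 in this assay is 40 nM, with a range from 12 nM to 130 nM.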

Compound 4, half-maximal effective concentration: 1.3 nM
For compound 4 the middle estimate is 31-fold (1.49 log units) above the measured one; the whole stated range lies above it.
By their numbers in this assay, from the lowest: compound 4; then compounds 2 and 3 (each within the scatter of the next); then compound 1.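

In this assay, the link to the saturated ring carbon proves to be a sensitive point in the series: with the 2,3-dihydro-1H-inden-1-yl group and the amine hydrogen kept, lengthening that link gives a 19-fold lower number from compound 1 to compound 4 (1.28 log units; beyond the scatter). For the compounds shown here, this step is larger than either earlier swap of the group on the amine nitrogen, a 5.0-fold lower number from compound 1 to compound 2 (0.70 log units; beyond the scatter) and a 2.7-fold lower number from compound 1 to compound 3 (0.43 log units; beyond the scatter), so the attachment to the ring carbon, which no earlier step altered, moves this number further than those swaps did. No measurement here bears on the reason for the size of this step.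

The compounds shown leave open whether the same lengthening would give a step of similar size with 4-acetamidobenzyl or 2-(carbamoyloxy)-1-phenylethyl on the amine nitrogen, since compound 4 carries only the 2,3-dihydro-1H-inden-1-yl group. They also leave open how the number responds to a longer chain in the link, or to an amide in place of the amine, so the limits of this effect remain undefined.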